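From nitro to acetoxy on the aromatic ring

The source may hold more compounds than are shown below. What is called first, only, known or untested is meant among the compounds shown, and "the series" means these compounds.

Compound 1 (`O=C1C=CCC/C1=C\C=C\c1ccc(F)cc1`) gives 2200 nM
Compound 2 (`O=C1C=CCC/C1=C\C=C\c1ccc(Cl)cc1`) gives 3500 nM
Compound 3 (`O=C1C=CCC/C1=C\C=C\c1ccc([N+](=O)[O-])cc1`) gives 5000 nM

These three values come from a functional assay on HCT-116 cells (Homo sapiens) for cytotoxicity, read by MTT assay, with a stated time of 72 h (a higher number here means a weaker inhibitor, a lower number a stronger inhibitor), and the compounds share one core, differing only in the group on the aromatic ring. Where compound 3 stands depends on the comparison: the numbers show a 2.3-fold higher number from compound 1 to compound 3 (0.36 log units; beyond the scatter) but also a 1.4-fold higher number from compound 2 to compound 3 (0.15 log units; within the scatter) and so it separates clearly from only one of the other two.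

The next compound, compound 4 (`CC(=O)Oc1ccc(/C=C/C=C2\CCC=CC2=O)cc1`), carries acetoxy in place of nitro on an aromatic carbon, para to a large group (acetoxy in place of nitro on an aromatic carbon). Going by the values given here, no measured compound carries acetoxy, so the guide is what earlier swaps at this same place did. Besides the two steps above, there is a 1.6-fold higher number from compound 1 to compound 2 (0.20 log units; within the scatter) and none of the three is large. Since the largest of them is a 2.3-fold higher number from compound 1 to compound 3 (0.36 log units; beyond the scatter) only a small move is likely here too. Expected in this assay is a 1.4-fold lower number from compound 3 to compound 4 (0.15 log units; within the scatter) and so no change beyond the scatter is foreseen. The estimate for compound 4 is 3500 nM (expected range 1500 nM to 8000 nM).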

Compound 4, half-maximal inhibitory concentration: 4600 nM
The estimate for compound 4 lay 1.3-fold (0.12 log units) below the measured number, within the range that was stated.
By their numbers in this assay, from the lowest: compounds 1, 2, 4 and 3 (each within the scatter of the next, the first and the last beyond it).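

In this assay acetoxy, with 4 heavy atoms against 3 for nitro and with carbon in the group, gives a 1.1-fold lower number from compound 3 to compound 4 (0.04 log units; within the scatter) in place of nitro, so this swap leaves the two compounds inseparable. Put against the halogens, acetoxy gives a 1.3-fold higher number from compound 2 to compound 4 (0.12 log units; within the scatter) from chloro but a 2.1-fold higher number from compound 1 to compound 4 (0.32 log units; beyond the scatter) from fluoro, which means compound 4 stands where compound 3 stood, clearly apart from compound 1 alone, and a fourth group at this place again produces only a small step. Nothing measured here explains why these groups give such close numbers.

From the compounds shown here alone, whether an amine or a carboxylic acid at this place would give a larger step than any seen so far remains open. So does whether these swaps would stay as small on a different core.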